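A few compounds are considered here, and "the series" means these few. Any claim that something is new, unique, unknown or untested is made for them only; others in the source may bear on it.

Compound 1, `O=C(Nc1ccccc1)c1cccc(Br)c1`, is the smaller of the two measured compounds. In an assay for inhibition of HSP60/HSP10 (Homo sapiens), with a stated time of 60 min (on this read-out higher numbers stand for weaker inhibition and lower numbers for stronger inhibition), compound 1 gives only a limit of the assay, > 100000 nM. Compound 2, `O=C(Nc1ccc(Sc2nc3ccccc3s2)cc1)c1ccccc1`, builds on the shared core with a larger group on the far ring. In this assay compound 2 likewise gives only a limit, > 100000 nM. Compound 2 therefore stands at the limit of > 100000 nM in this assay, at which 2 of the 2 values shown sit, and no order between the two measured compounds can be drawn. Compound 3, `O=C(Nc1ccc(Sc2nc3ccccc3s2)cc1)c1cccc(Br)c1`, differs from compound 2 in one place: bromo in place of hydrogen on an aromatic carbon, which cut one bond further out reads as phenyl to 3-bromophenyl. Within the data shown here, no measured step between compounds that differ in one place is available, so the size of this step is uncertain. Compound 1 carries the same bromo group and gives only a limit, > 100000 nM. The step is expected to be a step that the limit leaves unreadable from compound 2 to compound 3, nothing beyond the scatter. Compound 3 is expected to give 150000 nM, within 30000 nM to 1000000 nM, most likely again only as a limit.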

Compound 3, half-maximal inhibitory concentration: > 100000 nM
Compound 3: a limit, no number (the forecaster's own chance of this, stated with the estimate: 80%); the middle value is on the limit's open side.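

In this assay compound 3 gives only a limit, > 100000 nM. Among these compounds, compound 2 also gives only a limit, so no step from compound 2 to compound 3 can be read. The compounds shown leave open whether bromo in place of hydrogen changes inhibition, and what inhibition any of them reaches.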